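A few compounds are considered here, and "the series" means these few. Any claim that something is new, unique, unknown or untested is made for them only; others in the source may bear on it.

Compound 1, `O=C1NC(=O)C(Cc2ccc(Oc3cccc(Cl)c3)cc2)S1`: in a functional assay for agonist activity at Free fatty acid receptor 1 (Homo sapiens), read by FLIPR, in the presence of a further agent that is not named here (on this read-out higher numbers stand for an effect only at larger amounts of compound and lower numbers for an effect already at smaller amounts), compound 1 gives 318 nM.
Compound 2, `Cc1ccc(Oc2ccc(CC3SC(=O)NC3=O)cc2)cc1`: in this assay compound 2 gives 547 nM.

For the measured compounds named here, compound 2 is one of only two measured compounds, and the single measured step, a 1.7-fold higher number from compound 1 to compound 2 (0.24 log units; within the scatter), lies within the scatter, so the two numbers cannot be told apart. Compound 3, `O=C1NC(=O)C(Cc2ccc(OCc3ccccc3)cc2)S1`, has not yet been measured in this assay. It differs from compound 2 in one place: benzyl in place of 4-methylphenyl on an oxygen on an aromatic ring. Going by the values given here, the only step that bears on this change is the one from compound 1 to compound 2, which also exchanges the group on that same oxygen and stays within the scatter. Nothing measured here speaks for a benzyl group in particular. Compound 3 is therefore expected to stay close to compound 2, with a 1.1-fold higher number from compound 2 to compound 3 (0.04 log units; within the scatter), no step beyond the scatter. The estimate for compound 3 in this assay is 600 nM, with a range from 200 nM to 2000 nM.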

Compound 3, half-maximal effective concentration: 6180 nM
Compound 3: middle estimate off by 10-fold (1.01 log units), on the low side; the measured number lies above the stated range.
By their numbers in this assay, from the lowest: compounds 1 and 2 (each within the scatter of the next); then compound 3.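

In this assay, the place on the oxygen on an aromatic ring proves far less forgiving than the earlier pair suggested: 4-methylphenyl and benzyl have the same atoms joined differently, yet that exchange gives an 11-fold higher number from compound 2 to compound 3 (1.05 log units; beyond the scatter) in the read-out. The exchange of 3-chlorophenyl for benzyl likewise gives a 19-fold higher number from compound 1 to compound 3 (1.29 log units; beyond the scatter) and so shows that both aryl groups stand clearly apart from benzyl, although they cannot be told apart from each other. Nothing measured here explains this difference.

The compounds shown leave open whether a chloro or methyl group on the ring of the benzyl would change the number. They also leave open where a longer chain such as phenethyl, or a benzoyl group with its carbonyl, would fall on that oxygen.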